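The source may report more compounds than this note shows. Statements on the series, on what has been measured and on what is new or still open speak of the compounds shown alone.

Within the data shown here, compound 2 `Cc1cccc(Nc2ncnc3oc(C)c(CO)c23)c1` is the only compound of the pair that carries a measured number: in a functional assay on A549 cells (Homo sapiens) for cytotoxicity, read by MTT assay, with a stated time of 72 h (on this read-out lower numbers stand for stronger inhibition and higher numbers for weaker inhibition), compound 2 gives 24000 nM. Compound 1 `CCOC(=O)c1c(C)oc2ncnc(Nc3cccc(C)c3)c12` gives > 1000000 nM in this assay, and this is a limit of the assay rather than a number. Among the measured compounds shown here, the one measured step, an at least 41-fold lower number from compound 1 to compound 2 (1.61 log units; beyond the scatter), is accordingly known only as a minimum. Compound 3 `CCCNC(=O)c1c(C)oc2ncnc(Nc3cccc(C)c3)c12` differs from compound 2 in one place: propylcarbamoyl in place of hydroxymethyl on an aromatic carbon. This change returns a carbonyl-bearing group to the position that carried one in compound 1, so a step running opposite to an at least 41-fold lower number from compound 1 to compound 2 (1.61 log units; beyond the scatter), toward higher numbers, is expected, though an amide need not follow an ester exactly. Compound 3 is therefore estimated at 200000 nM, with a range from 30000 nM to 1500000 nM. The expected step is an 8.3-fold higher number from compound 2 to compound 3 (0.92 log units; beyond the scatter), which is expected to lie beyond the scatter.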

Compound 3, half-maximal inhibitory concentration: > 1000000 nM
Compound 3 was reported as a limit; the forecaster's own chance of this, stated with the estimate: 40%; middle value at least 5.0-fold (0.69 log units) away from the limit.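

Of the groups shown on this aromatic carbon, hydroxymethyl in compound 2 is now the only one that gives a measured number in this assay, while the two carbonyl-bearing groups, ethoxycarbonyl and propylcarbamoyl, both end at a limit of the assay. Replacing hydroxymethyl with propylcarbamoyl gives an at least 41-fold higher number from compound 2 to compound 3 (1.61 log units; beyond the scatter), so the higher number seen with the ester recurs with an amide, and no compound shown goes against this. That step is known only as a minimum and the step between the ester and the amide cannot be read, because both compounds stand at the same limit: the limit of > 1000000 nM in this assay, at which 2 of the 3 values shown sit.

The compounds shown do not separate the carbonyl from the propyl chain as the feature that goes with the higher number. They also leave open how a carboxylic acid, an aminomethyl group or a longer hydroxyalkyl chain on this carbon would read in this assay.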